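The source may hold more compounds than are shown below. What is called first, only, known or untested is meant among the compounds shown, and "the series" means these compounds.

Compound 1 (`CC(Cl)C(=O)Nc1cc(C(=O)NC(N)=O)ccc1Cl`) gives > 20000 nM in a functional assay on CCRF-CEM cells (Homo sapiens) for antiproliferative activity, read by trypan blue exclusion, with a stated time of 72 h (on this read-out higher numbers stand for weaker inhibition and lower numbers for stronger inhibition), and this is a limit of the assay, not a number. Compound 2 (`COc1ccc(C(=O)NC(N)=O)cc1NC(=O)C(C)Cl`) gives > 20000 nM in this assay and this too is only a limit. Compound 2 therefore has no number of its own, and the data show only the limit of > 20000 nM in this assay, at which 2 of the 2 values shown sit, for this pair. Compound 3 (`COc1ccc(C(=O)NC(N)=O)cc1NC(=O)CCl`) departs from compound 2 by hydrogen in place of methyl on a saturated chain carbon bound to a carbonyl carbon and a chlorine atom and so turns 1-chloroethyl into chloromethyl, with hydrogen in place of methyl on a saturated chain carbon bound to a carbonyl carbon and a chlorine atom. Among the measured compounds shown here, the only measured guide is a step that the two limits leave unreadable from compound 1 to compound 2 and it offers no size to carry over to this change. No step beyond the scatter is therefore expected in this assay and no direction can be argued, though a number under the limit remains possible. The expected change is a number no higher from compound 2 to compound 3 (the limit leaves the size open) as an estimate only. For compound 3 the expected value is 20000 nM within an estimated range of 5000 nM to 60000 nM and the assay may well report a limit again.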

Compound 3, half-maximal inhibitory concentration: > 20000 nM
Compound 3: a limit, no number; the forecaster's own chance of this, stated with the estimate: 60%; the middle value lies on the limit itself.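

Compound 3 also ends at a limit and not at a number, so no step can be read from compound 2 to compound 3, nor between any of the compounds shown: the limit of > 20000 nM in this assay, at which 3 of the 3 values shown sit. These compounds leave open how strongly any of them inhibits, and whether methoxy for chloro or chloromethyl for 1-chloroethyl changes that at all.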